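A few compounds are considered here, and "the series" means these few. Any claim that something is new, unique, unknown or untested is made for them only; others in the source may bear on it.

Measured so far:
compound 1 `c1cncc(CNCCCCN(C[C@H]2Cc3ccccc3CN2)[C@H]2CCCc3cccnc32)c1` — > 30000 nM
compound 2 `c1ccc2c(c1)CN[C@@H](CN(CCCCNCc1ccncc1)[C@H]1CCCc3cccnc31)C2` — > 30000 nM
compound 3 `O=S1(=O)CCC(CNCCCCN(C[C@H]2Cc3ccccc3CN2)[C@H]2CCCc3cccnc32)CC1` — > 30000 nM

In a functional assay on cells for agonist activity at C-X-C chemokine receptor type 4 (Homo sapiens), read by fluorescence and calcium flux, with a stated time of 90 s (a lower number here means that less compound is needed, a higher number that more compound is needed for the effect), compound 1 returns only a limit, > 30000 nM, not a number. Compound 2 likewise returns only a limit in this assay, > 30000 nM. Compound 3 stands at the same limit in this assay, > 30000 nM, so its position on the numbers is known only as a boundary, not as a value. All three values sit at the same point: the limit of > 30000 nM in this assay, at which 3 of the 3 values shown sit. The steps between them are therefore unreadable: a step that the two limits leave unreadable from compound 1 to compound 2, a step that the two limits leave unreadable from compound 1 to compound 3 and a step that the two limits leave unreadable from compound 2 to compound 3 cannot be sized, since both ends of each are limits.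

Compound 4 `c1ccc2c(c1)CN[C@@H](CN(CCCCNC1CCCCC1)[C@H]1CCCc3cccnc31)C2` is not yet measured. It differs from compound 3 by cyclohexyl in place of (1,1-dioxothian-4-yl)methyl on an amine nitrogen. The three measured steps bear on the same amine nitrogen and the group on it, but none of them gives a readable size or direction, so nothing from them lets one predict a step beyond the scatter in this assay. The expectation is that compound 4 stays where compound 3 stands, with the step from compound 3 to compound 4 estimated as a step that the limit leaves unreadable from compound 3 to compound 4. Compound 4 is estimated at 40000 nM, in the range 10000 nM to 150000 nM, most likely reported again only as a limit.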

Compound 4, half-maximal effective concentration: > 30000 nM
Compound 4 was reported as a limit (the forecaster's own chance of this, stated with the estimate: 75%); the middle value lies beyond the limit too.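

In this assay compound 4 gives > 30000 nM, which is a limit and not a number. Its steps from compound 1, compound 2 and compound 3 therefore cannot be read: the limit of > 30000 nM in this assay, at which 4 of the 4 values shown sit. The compounds shown leave open how these groups on the amine nitrogen rank, and whether any of them would return a number rather than a limit.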